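The source may hold more compounds than are shown below. What is called first, only, known or untested is meant among the compounds shown, and "the series" means these compounds.

Working notes on the series. Compound 1 `CN1CCN(C(=O)/C=C/c2ccncc2-c2ccc3ccccc3c2)CC1` carries a 4-methylpiperazin-1-yl amide on the acrylamide and, in an assay on a protein complex for inhibition of CDK8/Cyclin C (Homo sapiens), with a stated time of 1 h (a lower number here means a stronger inhibitor, a higher number a weaker inhibitor), compound 1 gives 43.6 nM. Among the measured compounds shown here, the only other measured member is compound 2 `Cn1ncc2cc(-c3cnccc3/C=C/C(=O)N3CCOCC3)ccc21`, which differs from compound 1 in more than one place; in this assay compound 2 gives 356 nM. Of the two numbers, compound 1 has the lowest; the gap to compound 2 lies beyond the scatter, so compound 1 is the stronger of the two measured compounds. For the measured compounds named here, no single-change step between measured compounds is available, so the effect of an amide swap alone has not been seen.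

Compound 3 `COC1CN(C(=O)/C=C/c2ccncc2-c2ccc3ccccc3c2)C1` keeps the core of compound 1 and changes only the amide: 3-methoxyazetidin-1-yl in place of 4-methylpiperazin-1-yl on a carbonyl carbon. Both groups leaving and entering hold no hydrogen-bond donor and one acceptor, and the rest of the molecule is unchanged, so a step of only modest size is expected, most likely towards a somewhat higher number in this assay but possibly none beyond the scatter. The step of a 1.8-fold higher number from compound 1 to compound 3 (0.26 log units; within the scatter) is the expected one. Compound 3 is estimated at 80 nM in this assay, within 25 nM to 250 nM.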

Compound 3, half-maximal inhibitory concentration: 42.8 nM
Compound 3: the middle estimate sits 1.9-fold (0.27 log units) above what was measured; the range from low to high includes it.
By their numbers in this assay, from the lowest: compounds 3 and 1 (each within the scatter of the next); then compound 2.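

In this assay, among the compounds shown here, the first single-change step reads a 1.0-fold lower number from compound 1 to compound 3 (0.01 log units; within the scatter) and thus gives the first direct view of the amide on a carbonyl carbon: 3-methoxyazetidin-1-yl and 4-methylpiperazin-1-yl cannot be told apart here. For this pair, a six-membered non-aromatic ring with 2 hetero atoms and a four-membered non-aromatic ring with 1 hetero atom, at 7 and 6 heavy atoms, show no step beyond the scatter, so neither the ring size nor the second ring nitrogen of 4-methylpiperazin-1-yl is shown to be needed on the core of compound 1. No supporting evidence bears on why the two amides match.

As far as these compounds go, compound 2 differs from compound 1 and compound 3 in more than one place, so whether the same amide exchange would also leave the number unchanged on the core of compound 2 remains open. Also open, from the compounds shown here alone, is how far this tolerance extends at the carbonyl carbon, for instance to a dimethylamino group, a pyrrolidin-1-yl ring or an azetidine ring bearing a carboxylic acid.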